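The source may report more compounds than this note shows. Statements on the series, on what has been measured and on what is new or still open speak of the compounds shown alone.

Measured so far: compound 1 `COc1ccc(/C=N/n2c(SC)nnc2-c2cc(OC)c(OC)c(OC)c2)c(OC)c1`, compound 2 `COc1ccc(/C=N/n2c(SCc3ccccc3)nnc2-c2cc(OC)c(OC)c(OC)c2)c(OC)c1` and compound 3 `COc1cc(-c2nnc3n2NC(CC(=O)c2ccc(C)cc2)(c2ccccc2)S3)cc(OC)c1OC`.

In a functional assay on HepG2 cells (Homo sapiens) for cytotoxicity, read by MTT assay, with a stated time of 48 h (on this read-out lower numbers stand for stronger inhibition and higher numbers for weaker inhibition), compound 1 gives only a limit, > 200000 nM. In this assay compound 2 gives 60900 nM and compound 3 gives 580 nM, so compound 3 stands lowest of the two numbers. Compound 4 `CCOC(=O)CC1(c2ccccc2)Nn2c(nnc2-c2cc(OC)c(OC)c(OC)c2)S1` differs from compound 3 by ethoxy in place of 4-methylphenyl on a carbonyl carbon. Among the measured compounds shown here, no measured step concerns this carbonyl carbon; the only measured step, an at least 3.2-fold lower number from compound 1 to compound 2 (0.51 log units; beyond the scatter), sits at another place on the shared core and moved toward lower numbers when an aromatic ring entered. Compound 4 is expected to show a 3.1-fold higher number from compound 3 to compound 4 (0.49 log units; beyond the scatter) because an at least 3.2-fold lower number from compound 1 to compound 2 (0.51 log units; beyond the scatter) ran the other way as an aromatic ring arrived. Compound 4 is therefore estimated at 1800 nM, between 500 nM and 8000 nM.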

Compound 4, half-maximal inhibitory concentration: > 200000 nM
Compound 4 gave a limit, no number (the forecaster's own chance of this, stated with the estimate: 5%); middle value at least 110-fold (2.04 log units) from the limit.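

Putting ethoxy in place of 4-methylphenyl on a carbonyl carbon gives an at least 340-fold higher number from compound 3 to compound 4 (2.53 log units; beyond the scatter) in this assay. The earlier compounds shown here did not touch this position, and this step shows that the group on the carbonyl carbon strongly affects the read-out within the shared core. The size of the step is only a lower bound, because compound 4 gives a limit and not a number: the limit of > 200000 nM in this assay, at which 2 of the 4 values shown sit.

Going by these compounds, whether the aromatic ring or its methyl carries this difference stays open. A plain phenyl or a dimethylamino group on this carbonyl carbon would help to separate these possibilities.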